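Chlorophenyl positional change on the piperazine amine of compound 1

The compounds below may be only part of what the source reports. "The series", "measured", "known", "first", "only" and "open" are said of these compounds alone.

Measured so far:
compound 1, `Cc1nc(-c2ccccc2)c(C(=O)N2CCN(c3cccc(Cl)c3)CC2)o1`: 39.2 nM
compound 2, `COc1ccc(-c2nc(C)oc2C(=O)N2CCN(c3cccc(Cl)c3)CC2)cc1`: "not active" (no number reported)

In a functional assay on HL-60 cells (Homo sapiens) for inhibition, read by MTT assay, with a stated time of 72 h (on this read-out higher numbers stand for weaker inhibition and lower numbers for stronger inhibition), compound 1 gives 39.2 nM. Compound 2, `COc1ccc(-c2nc(C)oc2C(=O)N2CCN(c3cccc(Cl)c3)CC2)cc1`, is reported in this assay as "not active" (no number reported), without a number; the two share the same amide and ring-amine part and differ in the group on the oxazole, so the pair says nothing about the aryl group on the amine. Within the data shown here, compound 1 therefore stands on the only number in the set, with one further entry that carries no number.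

Compound 3, `Cc1nc(-c2ccccc2)c(C(=O)N2CCN(c3ccccc3Cl)CC2)o1`, is not yet measured. It differs from compound 1 by 2-chlorophenyl in place of 3-chlorophenyl on an amine nitrogen in a ring. The same atoms are kept and only the place of the chlorine on the phenyl ring bound to the ring nitrogen moves. Among the measured compounds shown here, no measured pair shows such a change here, so the size of the step is open. A modest step in this assay toward weaker inhibition, or none beyond the scatter, is expected: a 1.7-fold higher number from compound 1 to compound 3 (0.22 log units; within the scatter). Compound 3 is estimated at 65 nM, with a range from 20 nM to 220 nM.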

Compound 3, half-maximal inhibitory concentration: 124 nM
Beside the measured number, compound 3's estimate is 1.9-fold (0.28 log units) below it; the range from low to high includes it.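

In this assay, the change to 2-chlorophenyl in place of 3-chlorophenyl on the amine nitrogen in the ring gives a 3.2-fold higher number from compound 1 to compound 3 (0.50 log units; beyond the scatter), so this position responds to where the chlorine sits on the phenyl ring, even with the same atoms kept. The earlier compounds shown here could not show this: both carry 3-chlorophenyl at this position, and compound 2 has no number. Of the two placements shown, 3-chlorophenyl gives the lower number, a reading limited to compound 1 and compound 3, and no measurement shown here accounts for the step.

Going by these compounds, it remains open whether a chlorine is needed at this position at all, a question that plain phenyl or a methoxyphenyl group on the same ring nitrogen would address. Among these compounds, it is also open whether the step between the two chlorophenyl groups carries over to other groups on the shared core; the only such change, in compound 2, comes without a number.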